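Chain carbamates: phenylpentyl ester against hexyl ester

The compounds below may be only part of what the source reports. "The series", "measured", "known", "first", "only" and "open" are said of these compounds alone.

The series is followed in an assay on membranes from brain for inhibition of Fatty-acid amide hydrolase 1 (Rattus norvegicus); on this read-out higher numbers stand for weaker inhibition and lower numbers for stronger inhibition. Compound 1 `O=C(NC1CCCCC1)Oc1ccc2cccc(Br)c2c1` gives 174 nM in this assay. For compound 2 `O=C(NC1CCCCC1)OCCCCCc1ccccc1` this assay reports only a limit, > 30000 nM. For compound 3 `CCNC(=O)Oc1ccc(C)cc1` this assay likewise reports only a limit, > 30000 nM. Compound 2 thus sits at the limit of > 30000 nM in this assay, at which 2 of the 3 values shown sit; no number is known for it, only that it lies outside the working range of this assay.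

Compound 4 `CCCCCCOC(=O)NC1CCCCC1` differs from compound 2 by methyl in place of phenyl on a saturated chain carbon, five bonds along the chain from an oxygen next to a carbonyl group; cut one bond further out, the same difference reads benzyl to ethyl. Within the data shown here, no step between measured compounds covers this change, and because compound 2 itself gives only a limit, the step cannot be read against a measured starting number. Nothing in the set shows a chain carbamate of this kind with a measurable value in this assay.

The expectation is that compound 4 stays at or beyond the limit, so no step beyond the scatter is expected, a number no higher from compound 2 to compound 4 (the limit leaves the size open). Compound 4 is expected to give about 30000 nM, within 10000 nM to 100000 nM, with the likelier outcome that this assay again reports only a limit and no number.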

Compound 4, half-maximal inhibitory concentration: 3760 nM
Compound 4: middle estimate off by 8.0-fold (0.90 log units), on the high side; measured number outside the range, below it.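

In this assay, methyl in place of phenyl on a saturated chain carbon, five bonds along the chain from an oxygen next to a carbonyl group, gives an at least 7.9-fold lower number from compound 2 to compound 4 (0.90 log units; beyond the scatter). Among these compounds, compound 4 is the first chain carbamate in the set with a measured number rather than a limit, so a chain ester of this kind does not by itself put a compound outside the working range of this read-out, and the terminal group at this position matters. The full size of the step stays open, since what stands for compound 2 is only a limit: the limit of > 30000 nM in this assay, at which 2 of the 4 values shown sit.

The compounds shown do not tell whether the measurable value is particular to the hexyl ester or extends to a shorter or a longer chain. They also leave open what a phenyl at a different distance along the chain would give, and whether an amine or a carboxylic acid at the chain end would keep a measurable value.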